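The source may hold more compounds than are shown below. What is called first, only, known or untested is meant among the compounds shown, and "the series" means these compounds.

Measured so far in an in vivo ADME assay on the whole organism (strain Mongrel) for pharmacokinetics, with Canis familiaris (Canis lupus familiaris) as the target; a lower number here means slower removal, a higher number faster removal of the compound:
compound 1 `COc1ncc(C(=O)NC2(C(=O)N[C@H](C)c3ccc(-n4nc(Cl)c5ccccc54)cc3F)CC2)s1` gives 1.7 mL/min/kg
compound 2 `Cc1cncc(C(=O)NC2(C(=O)N[C@H](C)c3ccc(-n4nc(Cl)c5ccccc54)cc3F)CC2)c1` gives 4.3 mL/min/kg

Compound 2 stands at the higher of the two numbers in this assay; its nearest neighbour is compound 1, and the step of a 2.5-fold higher number from compound 1 to compound 2 (0.40 log units; beyond the scatter) lies beyond the scatter. Compound 3 `Cc1nnsc1C(=O)NC1(C(=O)N[C@H](C)c2ccc(-n3nc(Cl)c4ccccc43)cc2F)CC1` differs from compound 2 by 4-methyl-1,2,3-thiadiazol-5-yl in place of 5-methylpyridin-3-yl on a carbonyl carbon. Within the data shown here, only one measured step bears on this change, and it concerns a different pair of groups, so it gives just a rough guide to the size of step. Compound 3 is therefore expected to show a modest step of a 1.4-fold lower number from compound 2 to compound 3 (0.16 log units; within the scatter) downward, with an estimate of 3 mL/min/kg and a range from 1.5 mL/min/kg to 7 mL/min/kg.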

Compound 3, clearance: 9.6 mL/min/kg
The estimate for compound 3 lay 3.2-fold (0.51 log units) below the measured number; measured number above the stated range.
By their numbers in this assay, from the lowest: compound 1; then compound 2; then compound 3.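

In this assay, the ring on the carbonyl carbon matters: 4-methyl-1,2,3-thiadiazol-5-yl in place of 5-methylpyridin-3-yl gives a 2.2-fold higher number from compound 2 to compound 3 (0.35 log units; beyond the scatter). Against 2-methoxy-1,3-thiazol-5-yl, the same group gives a 5.6-fold higher number from compound 1 to compound 3 (0.75 log units; beyond the scatter), so the two five-membered rings sit at opposite ends of these three compounds, and ring size alone does not set the order. Nothing measured here accounts for these steps. Going by these compounds, it remains open whether the methyl or the methoxy group drives the difference, and where a ring bearing an amine or a carboxylic acid would fall.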